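This account rests on a few compounds, and the source may have more. Where it says the series, first, only, none or still open, it means among the compounds named here.

Three compounds have been measured in a functional assay on HepG2 cells (Homo sapiens) for inhibition, read by MTT assay, with a stated time of 72 h; on this read-out lower numbers stand for stronger inhibition and higher numbers for weaker inhibition:

Compound 1 `N#Cc1ccccc1-n1cc(COc2cccc(NC(=O)Nc3ccc(Cl)c(C(F)(F)F)c3)c2)nn1`: 1970 nM
Compound 2 `Cc1ccc(-n2cc(COc3cccc(NC(=O)Nc4ccc(Cl)c(C(F)(F)F)c4)c3)nn2)cc1`: 5430 nM
Compound 3 `O=C(Nc1cccc(OCc2cn(-c3cccc(F)c3)nn2)c1)Nc1ccc(Cl)c(C(F)(F)F)c1`: 2120 nM

All three share the same core and differ only in the aromatic group attached to the aromatic nitrogen. Compound 1 gives the lowest number of the three in this assay. Its gap to compound 3 is small: a 1.1-fold higher number from compound 1 to compound 3 (0.03 log units; within the scatter). Its gap to compound 2 is larger: a 2.8-fold higher number from compound 1 to compound 2 (0.44 log units; beyond the scatter).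

Compound 4 `O=C(Nc1cccc(OCc2cn(-c3ccccc3Br)nn2)c1)Nc1ccc(Cl)c(C(F)(F)F)c1` has not yet been measured. It differs from compound 1 in one place: bromo in place of cyano on an aromatic carbon. Cut one bond further out, this reads as 2-cyanophenyl to 2-bromophenyl.

Among the measured compounds shown here, none of the measured steps swaps one group for another on the same aromatic carbon. The two steps from compound 1 change the whole attached ring: the move to 3-fluorophenyl stayed within the scatter, while the move to 4-methylphenyl gave a modest weakening. Both suggest this part of the molecule tolerates change without large shifts. The expectation for compound 4 is therefore a step of about a 1.3-fold higher number from compound 1 to compound 4 (0.10 log units; within the scatter), at most modest and possibly within the scatter. Compound 4 is estimated at 2500 nM, with a range from 1000 nM to 6500 nM.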

Compound 4, half-maximal inhibitory concentration: 2810 nM
Beside the measured number, compound 4's estimate is 1.1-fold (0.05 log units) below it; low and high end bracket the measured number.
By their numbers in this assay, from the lowest: compounds 1, 3, 4 and 2 (each within the scatter of the next, the first and the last beyond it).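

Among the compounds shown here, this is the first comparison in which the attached ring stays the same and only the group on its aromatic carbon, ortho to a large group, changes: in this assay, the swap of cyano for bromo gives a 1.4-fold higher number from compound 1 to compound 4 (0.15 log units; within the scatter), so at this position the read-out does not separate the two groups. The 2-bromophenyl ring also cannot be told apart from the 3-fluorophenyl ring, with a 1.3-fold higher number from compound 3 to compound 4 (0.12 log units; within the scatter), or from the 4-methylphenyl ring, with a 1.9-fold lower number from compound 2 to compound 4 (0.29 log units; within the scatter), which places compound 4 within the scatter of compound 2 even though compound 1 and compound 3 each stand beyond the scatter from compound 2. No independent measurement is available to explain why these groups read so much alike.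

The compounds shown leave open whether this carbon accepts something quite different, such as an amine, a carboxylic acid or a longer alkyl chain, any of which might move the number well beyond the scatter. They also leave open whether bromo and cyano would stay indistinguishable at other places on this ring, or in cells other than those used here.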